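Shortening the alkyne chain in compounds tested against sphingosine kinase 1

The source may report more compounds than this note shows. Statements on the series, on what has been measured and on what is new or still open speak of the compounds shown alone.

Measured compounds:
- compound 1, `CCCCC#CC(=O)[C@H](CO)NC(=O)OC(C)(C)C`: "not active" (no number reported)
- compound 2, `CCCCCCCCCCCCCC#CC(=O)[C@@H]1COC(C)(C)N1C(=O)OC(C)(C)C`: 54.7%
- compound 3, `CCCCCCCCCCCCCC#CC(=O)[C@H](CO)NC(=O)OC(C)(C)C`: 56.9%

Of the compounds shown here, three have been tested in an assay on CHO cells for inhibition of sphingosine kinase 1 (Homo sapiens), tested at 10 uM; on this read-out higher numbers stand for more inhibition at the one concentration tested (going by the name of the read-out) and lower numbers for less inhibition. Compound 1 is reported there only as "not active" (no number reported), without a number. Compound 2 gives 54.7% in this assay, and compound 3 gives 56.9%. These two numbers lie within the usual scatter of each other, so no order can be read between compound 2 and compound 3; compound 3 simply stands as one of the two compounds for which a number was obtained.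

The next compound, compound 4, `CCCCCCCCC#CC(=O)[C@H](CO)NC(=O)OC(C)(C)C`, has not yet been measured in this assay. It differs from compound 3 in one place: hydrogen in place of pentyl on a saturated chain carbon, eight bonds along the chain from a triple-bonded carbon. Going by the values given here, no measured pair shows this particular change, so its effect must be guessed from what is known. Compound 1 is reported as "not active" (no number reported) in this assay, while compound 3 gives 56.9%; compound 4 lies between them in structure. A downward step is therefore expected for compound 4, about a number 31.9 percentage points lower from compound 3 to compound 4 (beyond the scatter), beyond the scatter. Compound 4 is estimated to give 25%, within 5% to 50%.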

Compound 4, a percentage reported as inhibition, at one concentration (the size of the read-out at that concentration, not a potency): 4.2%
For compound 4 the middle estimate is 20.8 percentage points above the measured one; the measured number lies below the stated range.
By their numbers in this assay, from the lowest: compound 4; then compounds 2 and 3 (each within the scatter of the next).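

In this assay, hydrogen in place of pentyl on a saturated chain carbon, eight bonds along the chain from a triple-bonded carbon, gives a number 52.7 percentage points lower from compound 3 to compound 4 (beyond the scatter). Going by these compounds alone, this is the first step measured at this position, and it shows that the outer pentyl stretch of the chain matters greatly for inhibition at the one concentration tested, and that most of the inhibition is already gone at this chain length, well before the still shorter chain of compound 1, which is reported as "not active" (no number reported). Nothing available explains why removing this stretch has so large an effect.

The compounds shown leave open whether inhibition returns gradually or suddenly at chain lengths lying between those of compound 4 and compound 3, and whether a longer chain than that of compound 3 would give still more inhibition. They also leave open whether an amine or a carboxylic acid at the end of the chain could replace the pentyl stretch, and whether the ring-closed form seen in compound 2 would respond to chain shortening in the same way.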